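The source may hold more compounds than are shown below. What is called first, only, known or untested is meant among the compounds shown, and "the series" means these compounds.

Compounds measured in a functional assay on CHO cells for agonist activity at Free fatty acid receptor 1 (Homo sapiens), read by FLIPR and calcium flux; a higher number here means that more compound is needed for the effect, a lower number that less compound is needed:
- compound 1 `Cc1ccc(OCC(C)C)cc1-c1cccc(COc2ccc(OCC(=O)O)c(F)c2)c1` gives 1450 nM
- compound 2 `Cc1ccc(OCC2CC2)cc1-c1cccc(COc2ccc(OCC(=O)O)c(F)c2)c1` gives 340 nM
- compound 3 `Cc1ccc(OCC2CCCC2)cc1-c1cccc(COc2ccc(OCC(=O)O)c(F)c2)c1` gives 490 nM

Compound 1 shows the highest number of the three; the nearest is compound 3 and the furthest is compound 2. Compound 4 `Cc1ccc(OCCC2CCCCC2)cc1-c1cccc(COc2ccc(OCC(=O)O)c(F)c2)c1` is not yet measured. It differs from compound 1 by cyclohexylmethyl in place of isopropyl on a saturated chain carbon bound to an oxygen on an aromatic ring. Two measured steps start from the same place: a 4.3-fold lower number from compound 1 to compound 2 (0.63 log units; beyond the scatter) and a 3.0-fold lower number from compound 1 to compound 3 (0.47 log units; beyond the scatter). Both swap isopropyl for a carbon ring and both lower the number beyond the scatter, while the two ring compounds lie within the scatter of each other. A modest step downward in this assay is therefore expected for compound 4, a 2.9-fold lower number from compound 1 to compound 4 (0.46 log units; beyond the scatter). Compound 4 is estimated at 500 nM, with a range from 200 nM to 1500 nM.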

Compound 4, half-maximal effective concentration: 520 nM
Compound 4: middle estimate off by 1.0-fold (0.02 log units), on the low side, and the stated range covers the measured number.
By their numbers in this assay, from the lowest: compounds 2, 3 and 4 (each within the scatter of the next); then compound 1.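

In this assay the gain over isopropyl survives with the larger cyclohexylmethyl and its six-membered ring, at a 2.8-fold lower number from compound 1 to compound 4 (0.45 log units; beyond the scatter) and so beyond the scatter. Compared with the other two ring compounds, the steps are a 1.1-fold higher number from compound 3 to compound 4 (0.03 log units; within the scatter) and a 1.5-fold higher number from compound 2 to compound 4 (0.18 log units; within the scatter) and both lie within the scatter, so these three carbon-ring groups cannot be put in order at this position. Nothing shown here explains why these groups give such similar numbers. Still open, going by these compounds, is whether a phenyl ring in place of the cyclohexyl would keep the number at this level. An amine or a hydroxyl on this chain is equally untested here.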